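The source may hold more compounds than are shown below. What is called first, only, known or untested is meant among the compounds shown, and "the series" means these compounds.

Compound 2 `CC(C)c1cc(F)c(Cc2cnc(Nc3ccc(C#N)c(Cl)c3)o2)c(F)c1` and compound 1 `Cc1cc(F)c(Cc2cnc(Nc3ccc(C#N)c(Cl)c3)o2)c(F)c1` share one core and differ only in the group carried on the aromatic carbon that sits between the two fluoro groups. In an ADME assay on MT2 cells (Homo sapiens) for inhibition (a lower number here means that less compound is tolerated, a higher number that more compound is tolerated), compound 1 gives 31000 nM, while compound 2 gives 5000 nM, the lowest of the two numbers recorded so far; the step of a 6.2-fold lower number from compound 1 to compound 2 (0.79 log units; beyond the scatter) shows that a larger group at this position moved the number down. Compound 3 `CCOc1cc(F)c(Cc2cnc(Nc3ccc(C#N)c(Cl)c3)o2)c(F)c1` carries ethoxy in place of isopropyl on an aromatic carbon. For the measured compounds named here, the only measured step, a 6.2-fold lower number from compound 1 to compound 2 (0.79 log units; beyond the scatter), bears on this change, since it also alters the group at the same carbon, but it offers no guidance on an oxygen-containing group of the same size. Compound 3 is therefore expected to land in the region of compound 2, with a step of a 1.8-fold higher number from compound 2 to compound 3 (0.26 log units; within the scatter) that may well stay within the scatter. The estimate for compound 3 in this assay is 9000 nM, within a range from 3000 nM to 35000 nM.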

Compound 3, half-maximal cytotoxic concentration: 15000 nM
Compound 3: middle estimate off by 1.7-fold (0.22 log units), on the low side; the range from low to high includes it.
By their numbers in this assay, from the lowest: compound 2; then compound 3; then compound 1.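

In this assay, isopropyl and ethoxy carry the same count of heavy atoms, yet exchanging them gives a 3.0-fold higher number from compound 2 to compound 3 (0.48 log units; beyond the scatter) and this lies beyond the scatter, so the number at this carbon does not follow heavy-atom count alone. Ethoxy in place of methyl gives a 2.1-fold lower number from compound 1 to compound 3 (0.32 log units; beyond the scatter) and this also lies beyond the scatter, which puts the ethoxy compound in the middle of the three, with neither the lowest nor the highest number. Nothing available explains why ethoxy and isopropyl differ here.

The compounds shown leave open whether the oxygen itself accounts for the difference, which a comparison with a propyl chain at the same carbon could address. They also leave open how a longer ether such as propoxy, or an amine at this carbon, would read in this assay.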